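This account rests on a few compounds, and the source may have more. Where it says the series, first, only, none or still open, it means among the compounds named here.

Compound 1 `COc1cc2ncnc(NNC(=S)NC(=O)c3ccccc3C)c2cc1OC`: 19300 nM
Compound 2 `O=C(NC(=S)NNc1ncnc2ccccc12)c1ccc(C(F)(F)F)cc1`: 8050 nM
Compound 3 `O=C(NC(=S)NNc1ncnc2ccccc12)c1cccc(Cl)c1`: 3540 nM

In a functional assay on MCF7 cells (Homo sapiens) for cytotoxicity, read by MTT assay, with a stated time of 72 h (a lower number here means a stronger inhibitor, a higher number a weaker inhibitor), compound 3 gives the lowest number of the three; compound 2 lies higher by a gap beyond the scatter, and compound 1 higher still. Compound 4 `O=C(NC(=S)NNc1ncnc2ccccc12)c1ccccc1Cl` is built from the same atoms as compound 3, joined differently, with one change on the carbonyl carbon: 2-chlorophenyl in place of 3-chlorophenyl on a carbonyl carbon. Going by the values given here, no pair of measured compounds differs by a single change, so the size of such a step cannot be read from these data. The change is expected to move the number only a little, if at all beyond the scatter, so the estimated step from compound 3 to compound 4 in this assay is a 1.4-fold higher number from compound 3 to compound 4 (0.15 log units; within the scatter). Compound 4 is therefore expected to give 5000 nM, within a range of 2000 nM to 15000 nM.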

Compound 4, half-maximal inhibitory concentration: 10500 nM
Estimate against measurement, compound 4: 2.1-fold (0.32 log units) below, and the stated range covers the measured number.
By their numbers in this assay, from the lowest: compound 3; then compounds 2, 4 and 1 (each within the scatter of the next, the first and the last beyond it).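

Going by these compounds alone, replacing 3-chlorophenyl with 2-chlorophenyl on a carbonyl carbon gives the first single-change step that can be read in this assay, with a 3.0-fold higher number from compound 3 to compound 4 (0.47 log units; beyond the scatter). The two groups have the same atoms, so the way the chlorophenyl is joined at this place is enough to shift the number beyond the scatter, though the step is modest.

As far as these compounds go, whether a bromine in place of the chlorine of 3-chlorophenyl, or an amine there, would give a lower or a higher number remains open. Nothing given here accounts for the step.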